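Thiophen-3-yl to thiophen-2-yl: compound 2 to compound 3

A few compounds are considered here, and "the series" means these few. Any claim that something is new, unique, unknown or untested is made for them only; others in the source may bear on it.

Of the compounds shown here, two have been measured so far in a functional assay on cells (Cancer cell lines, Homo sapiens) for inhibition; on this read-out higher numbers stand for weaker inhibition of growth and lower numbers for stronger inhibition of growth. Compound 1 `Cc1cc(-c2nc3sccn3c2/C=N/NC(=N)N)c(C)s1` gives 17800 nM. Compound 2 `N=C(N)N/N=C/c1c(-c2ccsc2)nc2n1CCS2` gives 28200 nM. These two values lie within the scatter of each other, so no order can be read between them, and compound 2 simply stands with compound 1 in the same range of the read-out. Within the data shown here, no pair of measured compounds differs in one place only, so the series offers no measured step to serve as a guide.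

Compound 3 `N=C(N)N/N=C/c1c(-c2cccs2)nc2n1CCS2` has not yet been measured. It keeps the core of compound 2 and carries thiophen-2-yl in place of thiophen-3-yl on an aromatic carbon. The two have the same atoms, joined differently. No step beyond the scatter is expected in this assay, in either direction, so the expectation stays anchored on compound 2 at 28200 nM. The estimated change is small: a 1.1-fold lower number from compound 2 to compound 3 (0.05 log units; within the scatter). For compound 3 the estimated value is 25000 nM, with an expected range of 11000 nM to 50000 nM.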

Compound 3, concentration for 50% growth inhibition: 22900 nM
Estimate against measurement, compound 3: 1.1-fold (0.04 log units) above; the measured number falls inside the stated range.
By their numbers in this assay, from the lowest: compounds 1, 3 and 2 (each within the scatter of the next).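

In this assay, among these compounds, thiophen-2-yl in place of thiophen-3-yl gives a 1.2-fold lower number from compound 2 to compound 3 (0.09 log units; within the scatter) and is the only measured step that changes one place alone. At this position, on an aromatic carbon of the five-membered aromatic ring with 2 nitrogen, the two attachments of the thiophene cannot be told apart on this read-out, so a change that keeps the same atoms and joins them differently has no readable effect here. Nothing at hand bears on why the two compounds fall together, and the result rests on this single pair.

On these data alone, whether this position tolerates anything other than a thiophene stays open, since a single swap between two isomers says nothing about what a phenyl ring, a pyridine, a small alkyl chain or a primary amine at the same place would do to the growth read-out. Also open, as far as these compounds go, is how far the shared core contributes, as compound 1 differs from compound 2 and compound 3 in more than one place and so offers no clean comparison with either.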